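A few compounds are considered here, and "the series" means these few. Any claim that something is new, unique, unknown or untested is made for them only; others in the source may bear on it.

In a functional assay on A549 cells (Homo sapiens) for antiproliferative activity, read by MTT assay, with a stated time of 48 h (on this read-out lower numbers stand for stronger inhibition and higher numbers for weaker inhibition), compound 1 `O=[N+]([O-])c1cccc(-c2nn(-c3ccccc3)cc2C(Nc2nc3ccccc3s2)c2c(O)ccc3ccccc23)c1` gives 32000 nM and compound 2 `Cc1ccc2nc(NC(c3cn(-c4ccccc4)nc3-c3cccc([N+](=O)[O-])c3)c3c(O)ccc4ccccc34)sc2c1` gives 57400 nM. Within the data shown here, these are the only two numbers known, and they lie within the scatter of each other, so compound 1 cannot be separated from its sole neighbour. Compound 3 `Oc1ccc2ccccc2c1C(Nc1nc2ccccc2s1)c1cn(-c2ccccc2)nc1-c1ccccc1` departs from compound 1 by one change: hydrogen in place of nitro on an aromatic carbon, or 3-nitrophenyl to phenyl. Among the measured compounds shown here, the only measured step, a 1.8-fold higher number from compound 1 to compound 2 (0.25 log units; within the scatter), is methyl in place of hydrogen on an aromatic carbon; it stays within the scatter and does not involve the nitro. For the measured compounds named here, no measured step speaks to losing that group, so the data favour no direction, and no change beyond the scatter is expected in this assay. The estimated step is a 1.1-fold higher number from compound 1 to compound 3 (0.04 log units; within the scatter). For compound 3 the expected value is 35000 nM, with an estimated range of 12000 nM to 90000 nM.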

Compound 3, half-maximal inhibitory concentration: 36200 nM
Compound 3: the middle estimate sits 1.0-fold (0.01 log units) below what was measured; low and high end bracket the measured number.
By their numbers in this assay, from the lowest: compounds 1, 3 and 2 (each within the scatter of the next).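

In this assay, hydrogen in place of nitro on an aromatic carbon gives a 1.1-fold higher number from compound 1 to compound 3 (0.05 log units; within the scatter). The earlier compounds shown here offered only a methyl step and said nothing about the nitro; compound 3 now shows that, at this place on the ring, the 3-nitrophenyl and phenyl forms cannot be told apart in this read-out, so the nitro is not needed for the activity seen here. No measurement at hand accounts for this result.

From the compounds shown here alone, whether another group at this place, such as an amine, a carboxylic acid or a methoxy, would move the number beyond the scatter remains open. Going by these compounds, it is also open whether losing the nitro would have the same outcome in the methyl-bearing compound 2.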